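Swapping a fluorophenyl for a thiophene on the shared core

The source may report more compounds than this note shows. Statements on the series, on what has been measured and on what is new or still open speak of the compounds shown alone.

Three compounds share a core carrying a nitrile, a phenyl and a second phenyl group, and differ in two side groups. Compound 1 `N#Cc1c(-c2ccc(F)cc2)nc2c(c(-c3ccccc3)nn2-c2ccccc2)c1-c1ccc(O)cc1` gives 10200 nM in a functional assay on K562 cells (Homo sapiens) for antiproliferative activity, read by resazurin assay, with a stated time of 72 h; on this read-out higher numbers stand for weaker inhibition and lower numbers for stronger inhibition. Compound 2 `COc1cc(-c2c(C#N)c(-c3ccco3)nc3c2c(-c2ccccc2)nn3-c2ccccc2)ccc1O` gives 24900 nM in this assay, and compound 3 `COc1cc(-c2c(C#N)c(-c3cccs3)nc3c2c(-c2ccccc2)nn3-c2ccccc2)ccc1O` gives 15400 nM. Compound 1 thus has the lowest of the three numbers; the gap to compound 3 lies within the scatter, the gap to compound 2 beyond it. Among the compounds with values here, the one step that changes a single place is a 1.6-fold lower number from compound 2 to compound 3 (0.21 log units; within the scatter).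

Compound 4 `N#Cc1c(-c2cccs2)nc2c(c(-c3ccccc3)nn2-c2ccccc2)c1-c1ccc(O)cc1` is compound 1 with one change: thiophen-2-yl in place of 4-fluorophenyl on an aromatic carbon. Within the data shown here, no measured pair isolates this exact exchange. The step from compound 2 to compound 3 shows that swapping one five-membered heteroaromatic ring for another at this position barely moved the number, and compound 1 and compound 3, which differ at this position and at the hydroxyphenyl group, also sit close together. The exchange in compound 4 is therefore expected to give at most a small step, none beyond the scatter, so that a 1.2-fold higher number from compound 1 to compound 4 (0.07 log units; within the scatter) is the expected outcome. Compound 4 is accordingly estimated at 12000 nM in this assay, with a range from 5000 nM to 30000 nM.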

Compound 4, half-maximal inhibitory concentration: 11600 nM
Compound 4: middle estimate off by 1.0-fold (0.01 log units), on the high side; the measured number falls inside the stated range.
By their numbers in this assay, from the lowest: compounds 1, 4, 3 and 2 (each within the scatter of the next, the first and the last beyond it).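

In this assay, within the data shown here, thiophen-2-yl in place of 4-fluorophenyl gives a 1.1-fold higher number from compound 1 to compound 4 (0.06 log units; within the scatter); this is the first direct comparison at this position, next to the ring nitrogen, between a six-membered aromatic ring of carbon only and a five-membered aromatic ring with a hetero atom, and the two compounds cannot be told apart. Among these compounds, the earlier step between compound 2 and compound 3 compared only two five-membered rings, so the range of aromatic rings seen to give numbers within the scatter of each other is now wider, though it still covers only these few groups. The second new comparison concerns a different place on the shared core: hydrogen in place of methoxy gives a 1.3-fold lower number from compound 3 to compound 4 (0.12 log units; within the scatter), which also stays within the scatter, and nothing available explains why either exchange gives so small a step.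

As far as these compounds go, all four compounds carry an aromatic ring at the position next to the ring nitrogen, so it remains open whether a dimethylamino group, a carboxylic acid or a longer alkyl chain there would give a step beyond the scatter. From the compounds shown here alone, the role of the hydroxyl group on the 4-hydroxyphenyl group also remains open, since it is present in all four compounds and no comparison shows the effect of replacing it with, for example, an amine.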